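Swapping acetyl for an aryl ketone on the piperazine amide

The source may report more compounds than this note shows. Statements on the series, on what has been measured and on what is new or still open speak of the compounds shown alone.

Compound 2 `CC(=O)N1CCN(Cc2nc3ccccc3n2Cc2cccc(C)c2)CC1` gives 70.3% in an assay on isolated protein for inhibition of aldehyde dehydrogenase 1A1 (Homo sapiens), read by spectrophotometry, tested at 10 uM; on this read-out higher numbers stand for more inhibition at the one concentration tested (going by the name of the read-out) and lower numbers for less inhibition. Compound 1 `CCc1ccc(C(=O)N2CCN(Cc3nc4ccccc4n3Cc3cccc(C)c3)CC2)cc1` gives 67%, so the two sit within the scatter of each other, and the step of a number 3.3 percentage points higher from compound 1 to compound 2 (within the scatter) shows that putting methyl in place of 4-ethylphenyl on the carbonyl carbon moved nothing beyond noise. Compound 3 `Cc1cccc(Cn2c(CN3CCN(C(=O)c4ccc(C(C)C)cc4)CC3)nc3ccccc32)c1` reverses that kind of change: 4-isopropylphenyl in place of methyl on a carbonyl carbon. Within the data shown here, because the one comparable step a number 3.3 percentage points higher from compound 1 to compound 2 (within the scatter) stayed within the scatter, the move a number 3.3 percentage points lower from compound 2 to compound 3 (within the scatter) is expected to stay within the scatter too. Compound 3 is therefore estimated at 67%, with a range from 56% to 78%.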

Compound 3, a percentage reported as inhibition, at one concentration (the size of the read-out at that concentration, not a potency): 67.6%
Compound 3: the middle estimate sits 0.6 percentage points below what was measured, and the stated range covers the measured number.
By their numbers in this assay, from the lowest: compounds 1, 3 and 2 (each within the scatter of the next).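

In this assay, 4-isopropylphenyl replaces methyl on the carbonyl carbon with a number 2.7 percentage points lower from compound 2 to compound 3 (within the scatter) and so, like 4-ethylphenyl, this much larger group leaves the read-out within noise of the small acetyl. Methyl in place of hydrogen on the saturated chain carbon, which turns the ethyl of compound 1 into the isopropyl of compound 3, gives a number 0.6 percentage points higher from compound 1 to compound 3 (within the scatter) and so adds no readable difference either. Nothing measured here explains why the number stays level across these changes. From the compounds shown here alone, whether an amine or a carboxylic acid on the aromatic ring would shift the read-out remains open. So does how these compounds compare at other concentrations, which a single concentration cannot show.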